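A few compounds are considered here, and "the series" means these few. Any claim that something is new, unique, unknown or untested is made for them only; others in the source may bear on it.

Of the compounds shown here, three have numbers so far. Compound 1 `COc1ccc(Cl)cc1C(=O)NCCC1CCN(S(=O)(=O)NC(=O)NC[C@@H]2C[C@@H]3C=C[C@@H]2C3)CC1` gives 37% in a functional assay on the whole organism (blood) with Rattus norvegicus as the target, with stated times of 24 h and 1 h, at a dose of 5 mg/kg by the intraperitoneal route; on this read-out lower numbers stand for a weaker effect and higher numbers for a stronger effect at the one dose given. Compound 2 `Cc1ncsc1C(=O)NCCC1CCN(S(=O)(=O)NC(=O)NC[C@@H]2C[C@@H]3C=C[C@@H]2C3)CC1` gives 11% in this assay, and compound 3 `COc1ccncc1C(=O)NCCC1CCN(S(=O)(=O)NC(=O)NC[C@@H]2C[C@@H]3C=C[C@@H]2C3)CC1` gives 14% in this assay. On these numbers compound 3 is second of three: its gap to compound 2 is within the scatter, and it lies well under compound 1, with a number 23 percentage points lower from compound 1 to compound 3 (beyond the scatter) and a number 26 percentage points lower from compound 1 to compound 2 (beyond the scatter) recorded as the two steps away from compound 1. The step of a number 3 percentage points higher from compound 2 to compound 3 (within the scatter) is within the scatter.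

Compound 4 `O=C(NC[C@@H]1C[C@@H]2C=C[C@@H]1C2)NS(=O)(=O)N1CCC(CCNC(=O)c2nc3ccccc3s2)CC1` is not yet measured. Its difference from compound 3 is 1,3-benzothiazol-2-yl in place of 4-methoxypyridin-3-yl on a carbonyl carbon. Among the measured compounds shown here, the measured steps that bear on this change are the two that swap the group on the carbonyl carbon between heteroaryl variants, a number 3 percentage points higher from compound 2 to compound 3 (within the scatter) and a number 23 percentage points lower from compound 1 to compound 3 (beyond the scatter): the first exchange of one heteroaryl group for another stays within the scatter, the second shows that a change at this carbon can move the number by a modest amount. For the measured compounds named here, no step covers a bicyclic group at this carbon, so the direction is open.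

Compound 4 is expected to stay near compound 3 in this assay, with the step of a number 6 percentage points higher from compound 3 to compound 4 (within the scatter) estimated as within the scatter. The estimate for compound 4 is 20%, in the range 5% to 40%.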

Compound 4, a percentage reported as activity, at one dose (the size of the read-out at that dose, not a potency): 24%
Beside the measured number, compound 4's estimate is 4 percentage points below it, and the stated range covers the measured number.
By their numbers in this assay, from the lowest: compounds 2, 3 and 4 (each within the scatter of the next, the first and the last beyond it); then compound 1.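

In this assay, 1,3-benzothiazol-2-yl on the carbonyl carbon cannot be told apart from 4-methoxypyridin-3-yl, with a number 10 percentage points higher from compound 3 to compound 4 (within the scatter), but it is separated from 4-methyl-1,3-thiazol-5-yl, with a number 13 percentage points higher from compound 2 to compound 4 (beyond the scatter). The exchange of one heteroaryl group for another at this carbon can therefore move the number beyond the scatter, which the pair of compound 2 and compound 3 did not show, while 5-chloro-2-methoxyphenyl stays clear of the new group, with a number 13 percentage points lower from compound 1 to compound 4 (beyond the scatter), and compound 1 remains the highest of the four. Nothing at hand gives a reason for these differences.

The compounds shown leave open whether the number for compound 1 depends on its chlorine, its methoxy group or both, and a plain phenyl group, a 5-chloro-2-methoxypyridinyl group or a benzothiazolyl group carrying a methoxy group or chlorine would separate these parts. Also open, on these data alone, is how an amine or a carboxylic acid on the aromatic group would read here, and, with a single dose in this read-out, how the four compounds would rank by potency.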